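Phenyl to cyclohexyl on the ring amide nitrogen

The compounds below may be only part of what the source reports. "The series", "measured", "known", "first", "only" and "open" are said of these compounds alone.

Measured compounds:
compound 1 `O=C1COc2ccc(-c3cnc(Cl)c(NS(=O)(=O)c4ccc(F)cc4)c3)cc2N1c1ccccc1` with 39800 nM in a functional assay on HCT-116 cells (Homo sapiens) for antiproliferative activity, read by MTT assay, with a stated time of 72 h; a higher number here means a weaker inhibitor, a lower number a stronger inhibitor
compound 2 `COc1ccc(N2C(=O)COc3ccc(-c4ccc(O)cc4)cc32)cc1` with 26100 nM in this assay

Among the compounds with values here, only two numbers exist, and compound 1 and compound 2 lie within the usual scatter of each other, so neither stands apart. Compound 3 `O=C1COc2ccc(-c3cnc(Cl)c(NS(=O)(=O)c4ccc(F)cc4)c3)cc2N1C1CCCCC1` has not been measured. It differs from compound 1 by cyclohexyl in place of phenyl on an amide-type nitrogen in a ring. Within the data shown here, no measured pair shows what this change does, so the expected step of a 1.0-fold higher number from compound 1 to compound 3 (0.00 log units; within the scatter) is none beyond the scatter, in no firm direction. Compound 3 is expected to give about 40000 nM in this assay, within a range from 13000 nM to 120000 nM.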

Compound 3, half-maximal inhibitory concentration: > 40000 nM
Compound 3: no number, only a limit; the forecaster's own chance of this, stated with the estimate: 20%; the middle value sits exactly at the limit.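

Compound 3 gives > 40000 nM in this assay, and this is a limit of the assay, not a number. Cyclohexyl in place of phenyl on the amide-type nitrogen in a ring therefore gives a number no lower from compound 1 to compound 3 (the limit leaves the size open), which is the first reading for this position. The size of the step cannot be read, because the result rests on a limit: the limit of > 40000 nM in this assay, at which 1 of the 3 values shown sits.

Going by these compounds, whether a methyl group or a ring carrying an amine at this nitrogen gives a lower number stays open. So does whether cyclohexyl acts the same way on the core of compound 2.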